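A few compounds are considered here, and "the series" means these few. Any claim that something is new, unique, unknown or untested is made for them only; others in the source may bear on it.

In an assay (strain Sprague-Dawley) for inhibition of Amine oxidase [flavin-containing] A (Rattus norvegicus), read by spectrophotometry, with a stated time of 5 min (a lower number here means a stronger inhibitor, a higher number a weaker inhibitor), compound 1 `CNC(=O)/C=C1/COc2cc(OS(=O)(=O)c3ccc([N+](=O)[O-])cc3)ccc21` gives 37 nM, while compound 2 `CNC(=O)/C=C1/COc2cc(OS(=O)(=O)c3ccc(OC)cc3)ccc21` gives 11 nM. Within the data shown here, the single step measured so far, a 3.4-fold lower number from compound 1 to compound 2 (0.53 log units; beyond the scatter), places compound 2 lowest of the two numbers, with compound 1 as its only neighbour. Compound 3 `CNC(=O)/C=C1/COc2c1ccc(OS(=O)(=O)c1ccc(OC)cc1)c2C` differs from compound 2 by methyl in place of hydrogen on an aromatic carbon. Among the measured compounds shown here, no measured step involves a change of this kind, so the nitro-to-methoxy step gives no direct guide. In this assay the expected step is a 1.1-fold higher number from compound 2 to compound 3 (0.04 log units; within the scatter), within the scatter. Compound 3 is therefore estimated at 12 nM, with a range from 4 nM to 40 nM.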

Compound 3, half-maximal inhibitory concentration: 7 nM
Beside the measured number, compound 3's estimate is 1.7-fold (0.23 log units) above it; low and high end bracket the measured number.
By their numbers in this assay, from the lowest: compounds 3 and 2 (each within the scatter of the next); then compound 1.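

In this assay, a methyl in place of hydrogen on this aromatic carbon, ortho to a fused ring and ortho to a large group, gives a 1.6-fold lower number from compound 2 to compound 3 (0.20 log units; within the scatter) and so the position can carry a methyl without a measurable loss of inhibition. Among these compounds, the earlier step changed a group on the other aromatic ring, so this is the first measured change on the shared core itself. Nothing available gives a reason for this result.

As far as these compounds go, whether an ethyl group, a chlorine atom or an amine on this carbon would be accepted as well remains open. So does whether the methyl would behave the same way with nitro in place of methoxy.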